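A few compounds are considered here, and "the series" means these few. Any claim that something is new, unique, unknown or untested is made for them only; others in the source may bear on it.

For the measured compounds named here, compound 1 `COc1cc(N)c(Cl)cc1C(=O)NC1CCN(CC2CCN(CC(C)CN)CC2)CC1` stands at the highest of the three numbers measured so far: in an assay on striatum for inhibition of 5-hydroxytryptamine receptor 4 (Cavia porcellus), read by radioligand binding (on this read-out higher numbers stand for weaker inhibition and lower numbers for stronger inhibition), compound 1 gives 14.3 nM. Compound 2 `COc1cc(N)c(Cl)cc1C(=O)NC1CCN(CC2CCN(C(=O)C(C)N)CC2)CC1` gives 5.06 nM in this assay, and compound 3 `COc1cc(N)c(Cl)cc1C(=O)NC1CCN(CC2CCN(C(=O)CN)CC2)CC1` gives 9.3 nM. The step of a 2.8-fold lower number from compound 1 to compound 2 (0.45 log units; beyond the scatter) lies beyond the scatter, whereas the step of a 1.5-fold lower number from compound 1 to compound 3 (0.19 log units; within the scatter) does not, and between the two amino-acyl compounds the step of a 1.8-fold higher number from compound 2 to compound 3 (0.26 log units; within the scatter) is likewise within the scatter.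

Compound 4 `COc1cc(N)c(Cl)cc1C(=O)NC1CCN(CC2CCN(C(=O)C(C)(C)N)CC2)CC1` differs from compound 1 by (1-amino-1-methylethyl)carbonyl in place of 2-(aminomethyl)propyl on an amine nitrogen in a ring. Like compound 2 and compound 3, it replaces the 2-(aminomethyl)propyl group with an amino-bearing carbonyl group, here the (1-amino-1-methylethyl)carbonyl. The two steps that bear on this change, a 2.8-fold lower number from compound 1 to compound 2 (0.45 log units; beyond the scatter) and a 1.5-fold lower number from compound 1 to compound 3 (0.19 log units; within the scatter), both ran toward lower numbers, one modestly beyond the scatter and one within it, while the added methyl that separates compound 2 from compound 3 made no difference beyond the scatter. Compound 4 is therefore expected to show a step of a 2.0-fold lower number from compound 1 to compound 4 (0.31 log units; beyond the scatter) in this assay, a small move toward a lower number. The estimate for compound 4 is 7 nM, with an expected range from 3 nM to 16 nM.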

Compound 4, half-maximal inhibitory concentration: 2.6 nM
Compound 4: middle estimate off by 2.7-fold (0.43 log units), on the high side; measured number outside the range, below it.
By their numbers in this assay, from the lowest: compounds 4, 2, 3 and 1 (each within the scatter of the next, the first and the last beyond it).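

Set against compounds 2 and 3, the (1-amino-1-methylethyl)carbonyl group shows that the amino-bearing carbonyl series on this amine nitrogen in a ring can sit clearly away from compound 3 as well as from compound 1: in this assay the change gives a 5.5-fold lower number from compound 1 to compound 4 (0.74 log units; beyond the scatter) and so joins compound 2, not compound 3, in moving beyond the scatter. The earlier pair showed no clear effect of substitution on the carbon carrying the amine, with a 1.8-fold higher number from compound 2 to compound 3 (0.26 log units; within the scatter) but the pair with two methyl groups against none gives a 3.6-fold lower number from compound 3 to compound 4 (0.55 log units; beyond the scatter) so this carbon does register once both methyl groups are present. A single further methyl does not separate the compounds, as a 1.9-fold lower number from compound 2 to compound 4 (0.29 log units; within the scatter) leaves compound 2 and compound 4 unresolved, and nothing at hand explains any of these steps.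

The compounds shown leave open whether a group larger than methyl on this carbon, such as ethyl, would carry the trend further, and whether the amine could give way to a hydroxyl. They also leave open how a 2-amino-2-methylpropyl group, which has the same two methyl groups but no carbonyl, would compare with compound 4 in this assay on this ring nitrogen.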